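Restoring an Aryl Group on the Ring Nitrogen

The source may hold more compounds than are shown below. What is called first, only, known or untested is meant among the compounds shown, and "the series" means these compounds.

Compound 1 `COc1ccc(C)cc1N1C(=O)CSC1c1cccc(C(=O)NCCCCc2ccccc2)c1` and compound 2 `COc1ccc(F)cc1N1C(=O)CSC1c1cccc(C(=O)NCCCCc2ccccc2)c1` carry a substituted phenyl on the amide-type nitrogen of the shared core, while compound 3 `CCN1C(=O)CSC1c1cccc(C(=O)NCCCCc2ccccc2)c1` carries an ethyl at that nitrogen. In a functional assay on U2OS cells (Homo sapiens) for inhibition, read by CCK-8 assay, with a stated time of 72 h, tested at 1 uM (on this read-out lower numbers stand for less inhibition and higher numbers for more inhibition at the one concentration tested (going by the name of the read-out)), compound 1 gives 30% and compound 2 gives 32%; the step of a number 2 percentage points higher from compound 1 to compound 2 (within the scatter) is within the scatter. In this assay compound 3 gives 13%, the lowest of the three numbers, and both steps to it, a number 17 percentage points lower from compound 1 to compound 3 (beyond the scatter) and a number 19 percentage points lower from compound 2 to compound 3 (beyond the scatter), lie beyond the scatter.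

Compound 4 `COc1cc(F)ccc1N1C(=O)CSC1c1cccc(C(=O)NCCCCc2ccccc2)c1` differs from compound 3 by 4-fluoro-2-methoxyphenyl in place of ethyl on an amide-type nitrogen in a ring. This change runs opposite to the two measured steps that removed an aryl group from that nitrogen, so a rise of a similar size is expected in this assay for compound 4, namely a number 17 percentage points higher from compound 3 to compound 4 (beyond the scatter). The estimate for compound 4 in this assay is therefore 30%, with an expected range from 18% to 42%.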

Compound 4, a percentage reported as inhibition, at one concentration (the size of the read-out at that concentration, not a potency): 34%
The estimate for compound 4 lay 4 percentage points below the measured number; the range from low to high includes it.
By their numbers in this assay, from the lowest: compound 3; then compounds 1, 2 and 4 (each within the scatter of the next).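

In this assay, a third aryl group on the amide-type nitrogen in a ring gives a number 21 percentage points higher from compound 3 to compound 4 (beyond the scatter), so the difference between aryl and ethyl at this position now holds in the direction from ethyl to aryl as well, and for a further substitution pattern. The steps to compound 4 are small, with a number 2 percentage points higher from compound 2 to compound 4 (within the scatter) and a number 4 percentage points higher from compound 1 to compound 4 (within the scatter), so 4-fluoro-2-methoxyphenyl, 5-fluoro-2-methoxyphenyl and 2-methoxy-5-methylphenyl cannot be told apart in this read-out. No supporting data bear on why the aryl groups differ from ethyl here.

The compounds shown leave open whether the methoxy group matters, since every aryl group here carries one, and a plain phenyl would address that. They also leave open how a longer chain such as butyl, or a benzyl group, would compare with ethyl at this nitrogen.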